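The source may hold more compounds than are shown below. What is called first, only, known or untested is meant among the compounds shown, and "the series" means these compounds.

Compound 3, `CCc1ccc(N(CC(C)C)S(=O)(=O)c2ccc3cc(OCC4CCOCC4)c(C(=O)OC)cc3c2)cc1`, gives the highest number of the three measured compounds in a physicochemical assay for lipophilicity, at pH 7.4 (on this read-out higher numbers stand for higher lipophilicity and lower numbers for lower lipophilicity), at 6.09. Its nearest neighbour is compound 1, `CCc1ccc(N(CC(C)C)S(=O)(=O)c2ccc3cc(OCC4CCOCC4)c(CO)cc3c2)cc1`, which in this assay gives 5.1; the furthest is compound 2, `CCc1ccc(N(CC(C)C)S(=O)(=O)c2ccc(OCC3CCOCC3)c3c2CCC3=O)cc1`, which gives 4.44. Within the data shown here, the one single-point step among the measured compounds, a number 0.99 log units higher from compound 1 to compound 3 (beyond the scatter), runs to compound 3 from a hydroxymethyl group on the same core.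

Compound 4, `CCc1ccc(N(CC(C)C)S(=O)(=O)c2ccc3cc(OCC4CCOCC4)c(C(=O)OCC4CCOCC4)cc3c2)cc1`, differs from compound 3 by oxan-4-yl in place of hydrogen on a saturated chain carbon bound to an oxygen next to a carbonyl group. Among the measured compounds shown here, no measured step shows what adding an oxan-4-yl group at such a place does in this assay; the step of a number 0.99 log units higher from compound 1 to compound 3 (beyond the scatter) concerns a different change and gives only the starting point. The change from compound 3 to compound 4 adds six heavy atoms, five of them carbon, with one hydrogen-bond acceptor and no donor, and on this read-out such additions are generally expected to raise the number.

Compound 4 is therefore expected to come in above compound 3 by a number 0.81 log units higher from compound 3 to compound 4 (beyond the scatter), a step beyond the scatter. The estimate for compound 4 in this assay is 6.9, with a range from 6.3 to 7.5.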

Compound 4, distribution coefficient: 6.34
For compound 4 the middle estimate is 0.56 log units above the measured one, within the range that was stated.
By their numbers in this assay, from the lowest: compound 2; then compound 1; then compounds 3 and 4 (each within the scatter of the next).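

In this assay, oxan-4-yl in place of hydrogen on a saturated chain carbon bound to an oxygen next to a carbonyl group gives a number 0.25 log units higher from compound 3 to compound 4 (within the scatter), so the six heavy atoms it brings leave compound 4 and compound 3 within the scatter of each other. Against hydroxymethyl on the aromatic carbon, ((oxan-4-yl)methoxy)carbonyl gives a number 1.24 log units higher from compound 1 to compound 4 (beyond the scatter), which sets a second step beside a number 0.99 log units higher from compound 1 to compound 3 (beyond the scatter), so the step out of hydroxymethyl is now seen with two different carbonyl-bearing groups, and both lie beyond the scatter. Nothing available here explains why the added ring shifts the number by so little.

As far as these compounds go, what a carboxylic acid or a primary amide on the same aromatic carbon would give in this assay remains open, as does the reading for a free amine carried on the chain in place of oxan-4-yl. Also open, from the compounds shown here alone, is whether an open butyl chain or a piperidin-4-yl ring at the same place would stay as close to compound 3 as compound 4 does.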